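The compounds below may be only part of what the source reports. "The series", "measured", "known", "first", "only" and "open" are said of these compounds alone.

Compound 1 `O=C1N=C(N2CCC[C@H]2C(=O)Nc2ccc3ncnc(Nc4cccc(Cl)c4)c3c2)S/C1=C/c1cccnc1`: 10400 nM
Compound 2 `COc1ccccc1/C=C1/SC(N2CCC[C@H]2C(=O)Nc2ccc3ncnc(Nc4cccc(Cl)c4)c3c2)=NC1=O`: > 50000 nM
Compound 3 `O=C1N=C(N2CCC[C@H]2C(=O)Nc2ccc3ncnc(Nc4cccc(Cl)c4)c3c2)S/C1=C/c1cccc(Br)c1`: > 50000 nM

In a functional assay on A549 cells (Homo sapiens) for antiproliferative activity, read by MTT assay (on this read-out higher numbers stand for weaker inhibition and lower numbers for stronger inhibition), compound 1 gives 10400 nM. For compound 2 the reported value > 50000 nM is a limit of the assay and not a number. For compound 3 the value > 50000 nM is likewise a limit. Compound 2 therefore stands at the weak end of what has been measured, sitting at the limit of > 50000 nM in this assay, at which 2 of the 3 values shown sit. The move from pyridin-3-yl to 2-methoxyphenyl reads an at least 4.8-fold higher number from compound 1 to compound 2 (0.68 log units; beyond the scatter), the matching move to 3-bromophenyl reads an at least 4.8-fold higher number from compound 1 to compound 3 (0.68 log units; beyond the scatter), and between the two limit compounds the step is a step that the two limits leave unreadable from compound 2 to compound 3.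

Compound 4 `O=C1N=C(N2CCC[C@H]2C(=O)Nc2ccc3ncnc(Nc4cccc(Cl)c4)c3c2)S/C1=C/c1ccccc1Cl` has not been measured. It differs from compound 2 by chloro in place of methoxy on an aromatic carbon, or, cut one bond further out, 2-methoxyphenyl to 2-chlorophenyl. Within the data shown here, no measured step exchanges a single substituent on this ring. Among the measured compounds shown here, the steps that bear on it are an at least 4.8-fold higher number from compound 1 to compound 2 (0.68 log units; beyond the scatter) and an at least 4.8-fold higher number from compound 1 to compound 3 (0.68 log units; beyond the scatter), both beyond the scatter and both ending at the limit. The change in compound 4 is smaller than either of those, so compound 4 is expected to stay at the limit, with no movement beyond the scatter. The expected step is a step that the limit leaves unreadable from compound 2 to compound 4. Compound 4 is estimated to give 60000 nM, within 20000 nM to 200000 nM.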

Compound 4, half-maximal inhibitory concentration: > 50000 nM
Compound 4 ended at the assay's limit (the forecaster's own chance of this, stated with the estimate: 75%); the middle value is on the limit's open side.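

With chloro in place of methoxy on an aromatic carbon, ortho to a large group, compound 4 gives > 50000 nM in this assay, which is a limit of the assay and not a number. The steps to compound 4 from compound 2 and from compound 3 have a limit at both ends and cannot be read, so this exchange has no measurable size here. What is new is a third substituted phenyl group at this position: 2-chlorophenyl in place of pyridin-3-yl gives an at least 4.8-fold higher number from compound 1 to compound 4 (0.68 log units; beyond the scatter), and among the compounds shown only compound 1, the pyridin-3-yl compound, gives a value short of the limit: the limit of > 50000 nM in this assay, at which 3 of the 4 values shown sit.

On these data alone, how far compound 2, compound 3 and compound 4 lie past the limit remains unknown, so no order among 2-methoxyphenyl, 3-bromophenyl and 2-chlorophenyl can be drawn. The compounds shown also leave open whether an unsubstituted phenyl, a pyridin-2-yl or a phenyl carrying an amine or a carboxylic acid at this position would give a value short of the limit.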